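The source may hold more compounds than are shown below. What is called first, only, known or untested is meant among the compounds shown, and "the series" means these compounds.

Compound 1, `c1ccc(N2CCN(CCCCCOc3ccc4c(c3)CCC4)CC2)cc1`, in a functional assay on the whole organism for inhibition, with Mus musculus as the target, at a dose of 25 mg/kg by the oral route; on this read-out lower numbers stand for less inhibition and higher numbers for more inhibition at the one dose given (going by the name of the read-out): 25%
Compound 2, `Clc1cc(Cl)cc(N2CCN(CCCOc3ccc4c(c3)CCC4)CC2)c1`, in this assay: 0%

Compound 2 stands lowest of the two measured numbers, with compound 1 higher by a gap that is beyond the usual scatter. Compound 3, `O=[N+]([O-])c1ccc(N2CCN(CCCOc3ccc4c(c3)CCC4)CC2)cc1`, differs from compound 2 in one place: 4-nitrophenyl in place of 3,5-dichlorophenyl on an amine nitrogen in a ring. Among the compounds with values here, no measured pair covers this change, so its effect is unknown. A modest rise in this assay is expected, perhaps barely beyond the scatter. Compound 3 is estimated at 15%, between 0% and 45%, an expected step of a number 15 percentage points higher from compound 2 to compound 3 (beyond the scatter).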

Compound 3, a percentage reported as inhibition, in the whole organism at one dose (the size of the read-out at that dose, not a potency): 26%
The estimate for compound 3 lay 11 percentage points below the measured number; measured number inside the range.
By their numbers in this assay, from the lowest: compound 2; then compounds 1 and 3 (each within the scatter of the next).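

On the amine nitrogen in the six-membered ring, the choice of aryl group makes a clear difference: in this assay, 4-nitrophenyl in place of 3,5-dichlorophenyl gives a number 26 percentage points higher from compound 2 to compound 3 (beyond the scatter). This position therefore does not treat all substituted phenyl groups alike. Nothing measured here explains the rise.

On these data alone, whether it comes from gaining the nitro group or from losing the two chlorine atoms stays open. A 4-methoxyphenyl or 4-chlorophenyl group at this place, with the rest of compound 2 unchanged, would help separate these two readings.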